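A Fluoro-for-Methyl Swap on the Core of Compound 1

A few compounds are considered here, and "the series" means these few. Any claim that something is new, unique, unknown or untested is made for them only; others in the source may bear on it.

Compound 1 `Cc1ccc2nc(NC(=O)CNC(=O)c3nn(-c4ccccc4)c(=O)c4ccccc34)sc2c1`: 35 nM
Compound 2 `COc1ccc(-n2nc(C(=O)NCC(=O)Nc3nc4ccc(C)cc4s3)c3ccccc3c2=O)cc1`: 25 nM
Compound 3 `O=C(CSc1nc2c(c(=O)n1-c1ccccc1)SCC2)Nc1nc2ccc(C(F)(F)F)cc2s1`: 40 nM

In an assay on L cells for inhibition of Protein-serine O-palmitoleoyltransferase porcupine (Mus musculus), read by reporter gene assay, with a stated time of 24 h (on this read-out lower numbers stand for an effect already at smaller amounts and higher numbers for an effect only at larger amounts of compound), compound 1 stands second highest of the three numbers, nearest to compound 3 and furthest from compound 2, with both gaps within the scatter. For the measured compounds named here, the only measured step, a 1.4-fold lower number from compound 1 to compound 2 (0.15 log units; within the scatter), concerns a different part of the shared core and is itself within the scatter. Compound 3 carries a trifluoromethyl and another tail, and its value and that of compound 1 lie within the scatter of each other. Compound 4 `O=C(CNC(=O)c1nn(-c2ccccc2)c(=O)c2ccccc12)Nc1nc2ccc(F)cc2s1` differs from compound 1 by fluoro in place of methyl on an aromatic carbon. Going by the values given here, no measured step bears directly on this exchange, so compound 4 is expected to give 40 nM in this assay, between 15 nM and 110 nM, a step of a 1.1-fold higher number from compound 1 to compound 4 (0.06 log units; within the scatter) that is expected to stay within the scatter.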

Compound 4, half-maximal effective concentration: 470 nM
Compound 4: the middle estimate sits 12-fold (1.07 log units) below what was measured, outside the stated range (above it).
By their numbers in this assay, from the lowest: compounds 2, 1 and 3 (each within the scatter of the next); then compound 4.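

In this assay the exchange of 6-methyl-1,3-benzothiazol-2-yl for 6-fluoro-1,3-benzothiazol-2-yl gives a 13-fold higher number from compound 1 to compound 4 (1.13 log units; beyond the scatter) and is the only step shown that lies beyond the scatter. This position therefore responds strongly to a change of one heavy atom for another, with no change in rings, hydrogen-bond donors, hydrogen-bond acceptors or net charge. Nothing measured here accounts for the size of this step.

From the compounds shown here alone, whether chloro or ethyl at this position would stay close to compound 1 or move towards compound 4 remains open. So does whether the same exchange would have a similar effect on compound 2.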